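Aryl amide variation in the sulfonamide series

A few compounds are considered here, and "the series" means these few. Any claim that something is new, unique, unknown or untested is made for them only; others in the source may bear on it.

Compound 2 `Cc1ccc(S(=O)(=O)NCc2ccc(CNC(=O)c3ccncc3)cc2)cc1` gives 10 nM in an assay on MDA-MB-231 cells for binding affinity to C-X-C chemokine receptor type 4 (Homo sapiens), read by immunofluorescence and microscopy, with stated times of 10 min and 30 min (a higher number here means that more compound is needed for the effect, a lower number that less compound is needed), level with compound 3 `O=C(NCc1ccc(CNS(=O)(=O)c2ccccc2)cc1)c1ccccc1Cl` at 10 nM and together the highest of the three numbers; compound 1 `Cc1ccc(S(=O)(=O)NCc2ccc(CNC(=O)c3ccc(F)cc3)cc2)cc1` sits lowest at 1 nM. Compound 4 `Cc1ccc(S(=O)(=O)NCc2ccc(CNC(=O)c3ccccc3C)cc2)cc1` carries 2-methylphenyl in place of pyridin-4-yl on a carbonyl carbon. For the measured compounds named here, the one measured step that bears on this change is a 10-fold higher number from compound 1 to compound 2 (1.00 log units; beyond the scatter), where an aromatic ring of carbon only gave way to the ring with one nitrogen; compound 4 runs that exchange in the opposite direction. Going by the values given here, compound 3 also holds an aromatic ring of carbon only on the carbonyl carbon, yet its value matches compound 2, so that pair offers no step to lean on. A lower number is therefore expected for compound 4, a 3.3-fold lower number from compound 2 to compound 4 (0.52 log units; beyond the scatter). Compound 4 is estimated at 3 nM, range 1 nM to 15 nM.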

Compound 4, effective concentration (reported as EC, without a stated level of effect): 100 nM
The estimate for compound 4 lay 33-fold (1.52 log units) below the measured number; measured number outside the range, above it.
By their numbers in this assay, from the lowest: compound 1; then compounds 2 and 3 (each within the scatter of the next); then compound 4.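

In this assay, a ring of carbon only on the carbonyl carbon does not by itself give a low number: 2-methylphenyl in place of pyridin-4-yl brings a 10-fold higher number from compound 2 to compound 4 (1.00 log units; beyond the scatter). Against 4-fluorophenyl the same group gives a 100-fold higher number from compound 1 to compound 4 (2.00 log units; beyond the scatter), so the choice of carbon ring at this position moves the number further than the exchange of 4-fluorophenyl for pyridin-4-yl did. No measurement available here accounts for these steps.

Open, as far as these compounds go, is whether the rise follows the methyl group itself or its place on the ring. A phenyl or 4-methylphenyl group on the same carbonyl carbon would separate the two.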